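The compounds below may be only part of what the source reports. "The series", "measured", "known", "first", "only" and "open" are said of these compounds alone.

Compound 1 `N#CC1=C(N)Oc2c(N)cc3nc4ccccc4nc3c2C12C(=O)N(Cc1cnnn1-c1ccc([N+](=O)[O-])cc1[N+](=O)[O-])c1ccccc12` gives 18400 nM in a functional assay on HepG2 cells (Homo sapiens) for antiproliferative activity, read by MTT assay, with a stated time of 48 h; on this read-out higher numbers stand for weaker inhibition and lower numbers for stronger inhibition. Compound 2 `Cc1cc(C)c(-n2nncc2CN2C(=O)C3(C(C#N)=C(N)Oc4c(N)cc5nc6ccccc6nc5c43)c3ccccc32)c(C)c1` stands highest of the two numbers, giving 48100 nM in this assay; its nearest neighbour is compound 1, with a 2.6-fold higher number from compound 1 to compound 2 (0.42 log units; beyond the scatter). Compound 3 `COc1cc(-n2nncc2CN2C(=O)C3(C(C#N)=C(N)Oc4c(N)cc5nc6ccccc6nc5c43)c3ccccc32)c(OC)cc1Cl` differs from compound 2 by 4-chloro-2,5-dimethoxyphenyl in place of 2,4,6-trimethylphenyl on an aromatic nitrogen. For the measured compounds named here, no measured step tests this particular change; the single step available, a 2.6-fold higher number from compound 1 to compound 2 (0.42 log units; beyond the scatter), shows that exchanging the group on the aromatic nitrogen shifted the number only modestly. Compound 3 is therefore expected to shift little, a 1.4-fold lower number from compound 2 to compound 3 (0.14 log units; within the scatter). Compound 3 is estimated at 35000 nM in this assay, with a range from 12000 nM to 100000 nM.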

Compound 3, half-maximal inhibitory concentration: > 50000 nM
Compound 3: a limit, no number (the forecaster's own chance of this, stated with the estimate: 10%); middle value at least 1.4-fold (0.15 log units) away from the limit.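

In this assay compound 3 gives > 50000 nM, which is a limit of the assay and not a number. With an at least 1.0-fold higher number from compound 2 to compound 3 (0.01 log units; that floor lies within the scatter), only a floor is fixed, so 4-chloro-2,5-dimethoxyphenyl cannot be ordered against 2,4,6-trimethylphenyl on this aromatic nitrogen. There is, however, an at least 2.7-fold higher number from compound 1 to compound 3 (0.43 log units; beyond the scatter), so a second replacement of 2,4-dinitrophenyl also raises the number.

From the compounds shown here alone, how far the true value of compound 3 lies past its limit stays open, as does whether the methoxy groups or the chlorine account for the step. Also open, going by these compounds, is what an unsubstituted phenyl or an amine-bearing chain would give at this position.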